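Swapping an Alkyne Amine for a Phenyl Amino Alcohol

The source may report more compounds than this note shows. Statements on the series, on what has been measured and on what is new or still open speak of the compounds shown alone.

Compound 1: `NC(=O)OC[C@H](NC1CCN(CCCc2c[nH]c3ccc(-n4cnnc4)cc23)CC1)c1ccccc1` gives 4.7 nM.
Compound 2: `CC#CCN(C)C1CCN(CCCc2c[nH]c3ccc(-n4cnnc4)cc23)CC1` gives 9.8 nM.

Both compounds share one core and differ only in the group attached to the saturated ring carbon. In an assay on CHO cells for binding affinity to 5-hydroxytryptamine receptor 1D (Homo sapiens) (a lower number here means a stronger inhibitor, a higher number a weaker inhibitor), compound 2 stands at the higher of the two numbers, and compound 1 sits a step below it, a gap wider than the usual scatter.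

Compound 3, `CC(CO)(NC1CCN(CCCc2c[nH]c3ccc(-n4cnnc4)cc23)CC1)c1ccccc1`, is not yet measured. The change from compound 2 is (1-(hydroxymethyl)-1-phenylethyl)amino in place of (but-2-yn-1-yl)(methyl)amino on a saturated ring carbon. The entering group brings a phenyl ring and a hydroxyl, so compound 3 resembles compound 1 more than compound 2 at this place; compound 1, which bears a phenyl on its own amino group, gives 4.7 nM in this assay.

Compound 3 is therefore expected to give about 5 nM, within a range from 1.5 nM to 15 nM. That estimate means an expected step of a 2.0-fold lower number from compound 2 to compound 3 (0.29 log units; within the scatter) toward a stronger inhibitor.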

Compound 3, half-maximal inhibitory concentration: 5.2 nM
Estimate against measurement, compound 3: 1.0-fold (0.02 log units) below; low and high end bracket the measured number.
By their numbers in this assay, from the lowest: compounds 1, 3 and 2 (each within the scatter of the next, the first and the last beyond it).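

In this assay, putting (1-(hydroxymethyl)-1-phenylethyl)amino in place of (but-2-yn-1-yl)(methyl)amino on a saturated ring carbon gives a 1.9-fold lower number from compound 2 to compound 3 (0.28 log units; within the scatter) and so does not clearly change the number, even though the entering group is larger and carries a six-membered aromatic ring. On the amine nitrogen, 1-(hydroxymethyl)-1-phenylethyl in place of 2-(carbamoyloxy)-1-phenylethyl gives a 1.1-fold higher number from compound 1 to compound 3 (0.04 log units; within the scatter) and leaves these two phenyl-bearing groups indistinguishable in this assay. Nothing measured here explains why these different groups give such similar numbers.

Going by these compounds, it remains open how a plain benzyl group, with the aromatic ring but no hydroxymethyl, would behave on this amine nitrogen. The same question applies to a carboxylic acid in place of the hydroxymethyl.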